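This account rests on a few compounds, and the source may have more. Where it says the series, first, only, none or still open, it means among the compounds named here.

Measured in a functional assay on PC-3 cells (Homo sapiens) for cytotoxicity, read by MTT assay, with a stated time of 72 h; a lower number here means a stronger inhibitor, a higher number a weaker inhibitor:
- compound 1 `COc1cc2ncnc(Nc3ccc(F)c(Cl)c3)c2cc1NC(=O)N/N=C/c1ccc(C#N)cc1`: 36500 nM
- compound 2 `COc1cc2ncnc(Nc3ccc(F)c(Cl)c3)c2cc1NC(=O)N/N=C/c1ccc([N+](=O)[O-])cc1`: 32400 nM
- compound 3 `COc1cc2ncnc(Nc3ccc(F)c(Cl)c3)c2cc1NC(=O)N/N=C/c1ccc(O)c(Br)c1`: 15300 nM

Compound 3 holds the lowest of these numbers, but only by a modest margin: a 2.1-fold lower number from compound 2 to compound 3 (0.33 log units; beyond the scatter), and a 2.4-fold lower number from compound 1 to compound 3 (0.38 log units; beyond the scatter). Compound 4 `COc1cc2ncnc(Nc3ccc(F)c(Cl)c3)c2cc1NC(=O)N/N=C/c1ccc(O)cc1O` has 2,4-dihydroxyphenyl in place of 3-bromo-4-hydroxyphenyl on a carbon with a double bond to nitrogen. Among the measured compounds shown here, no measured compound carries this new group, so the evidence is indirect. Changes at this same place gave only modest steps, such as a 2.4-fold lower number from compound 1 to compound 3 (0.38 log units; beyond the scatter), while a 1.1-fold lower number from compound 1 to compound 2 (0.05 log units; within the scatter) stayed within the scatter. A small upward move in this assay is therefore expected, possibly no larger than the scatter. The expected change is a 1.5-fold higher number from compound 3 to compound 4 (0.18 log units; within the scatter). For compound 4 the estimated value is 23000 nM, with an expected range of 10000 nM to 50000 nM.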

Compound 4, half-maximal inhibitory concentration: 29500 nM
The estimate for compound 4 lay 1.3-fold (0.11 log units) below the measured number; measured number inside the range.
By their numbers in this assay, from the lowest: compounds 3, 4, 2 and 1 (each within the scatter of the next, the first and the last beyond it).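

In this assay, a 1.9-fold higher number from compound 3 to compound 4 (0.29 log units; within the scatter) comes with 2,4-dihydroxyphenyl in place of 3-bromo-4-hydroxyphenyl, so this swap cannot be told apart from no change. With a 1.1-fold lower number from compound 2 to compound 4 (0.04 log units; within the scatter) and a 1.2-fold lower number from compound 1 to compound 4 (0.09 log units; within the scatter) as well, the two hydroxyl groups of 2,4-dihydroxyphenyl do not set this compound apart from those carrying 4-nitrophenyl or 4-cyanophenyl. On these data alone, whether an amine or a carboxylic acid on this ring would give a clearly larger step stays open. Nothing measured here explains why these steps are small.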